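The compounds below may be only part of what the source reports. "The series", "measured", "known", "first", "only" and "open" are said of these compounds alone.

Compound 2 `O=C(O)CC/C=C\CC1COC(c2cccnc2)OC1c1cccnc1` sits with the second highest number of the three measured here in a functional assay for inhibition, with Homo sapiens as the target (a lower number here means tighter binding, a higher number weaker binding), where compound 2 gives 759 nM. Its nearest neighbour is compound 1 `O=C(O)CC/C=C\CC1COC(c2ccc(Cl)cc2Cl)OC1c1cccnc1`, which in this assay gives 891 nM; the step of a 1.2-fold lower number from compound 1 to compound 2 (0.07 log units; within the scatter) is within the scatter, so the two cannot be told apart on these numbers. Compound 3 `CC(C)(Oc1ccc(F)cc1[N+](=O)[O-])C1OCC(C/C=C\CCC(=O)O)C(c2cccnc2)O1` stands far away: in this assay compound 3 gives 2.51 nM, a much lower number than either of the other two.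

Compound 4 `CC(C)(Sc1ccccc1)C1OCC(C/C=C\CCC(=O)O)C(c2cccnc2)O1` is the untested compound. It differs from compound 2 in one place: a group of 10 heavy atoms (9 carbon, 1 sulfur; one six-membered aromatic ring of carbon only) in place of a group of 6 heavy atoms (5 carbon, 1 nitrogen; one six-membered aromatic ring with 1 hetero atom), on a saturated ring carbon. For the measured compounds named here, the one measured step at the same place, the step from compound 1 to compound 2, swapped one aromatic ring for another and moved the number only within the scatter. Compound 4 instead carries a group of the kind seen in compound 3, where the carbon between the two ring oxygens bears a larger branched substituent and the number is far lower than in compound 2. Going by the values given here, on that basis a sizeable drop in the number is expected, though compound 3 is the only guide and no direct step to it is given. Compound 4 is therefore expected to reach about 10 nM, somewhere between 2 nM and 60 nM, which would mean an estimated step of a 76-fold lower number from compound 2 to compound 4 (1.88 log units; beyond the scatter).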

Compound 4, dissociation constant: 200 nM
Beside the measured number, compound 4's estimate is 20-fold (1.30 log units) below it, and the stated range ends below it.
By their numbers in this assay, from the lowest: compound 3; then compound 4; then compounds 2 and 1 (each within the scatter of the next).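

In this assay, the swap at this saturated ring carbon, between two ring oxygen atoms, now moves the number beyond the scatter: the sulfur-bearing group of 10 heavy atoms gives modest steps (a 3.8-fold lower number from compound 2 to compound 4 (0.58 log units; beyond the scatter); a 4.5-fold lower number from compound 1 to compound 4 (0.65 log units; beyond the scatter)), unlike the earlier swap of one aromatic ring for another. A group of this general kind is still not enough to reach the low number of compound 3, as the large step (an 80-fold higher number from compound 3 to compound 4 (1.90 log units; beyond the scatter)) shows, so the outer part of the group matters greatly: there a part with sulfur stands in place of a part holding nitrogen, oxygen and fluorine. No independent data explain why either change moves the number as it does.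

Compounds 3 and 4 differ in their linking atom and their ring substituents all at once, so the share of the oxygen link, the nitro group and the fluorine in that large step remains unresolved. Also open, as far as these compounds go, is how the number would respond to a different substituent on that aromatic ring, such as an amine or a nitrile.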